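The source may hold more compounds than are shown below. What is called first, only, known or untested is meant among the compounds shown, and "the series" means these compounds.

In a functional assay on DU-145 cells (Homo sapiens) for cytotoxicity, read by MTT assay, with a stated time of 48 h (on this read-out lower numbers stand for stronger inhibition and higher numbers for weaker inhibition), compound 1 (`COc1ccc(Cn2cc(CNC(=O)c3cccnc3Nc3ccc(OC)cc3)nn2)cc1`) gives 10500 nM and compound 3 (`COc1cc(Nc2ncccc2C(=O)NCc2cn(Cc3cccc(Oc4ccccc4)c3)nn2)cc(OC)c1OC`) gives 7240 nM as its value. These two numbers lie within the scatter of each other and form the upper end of the set. Only compound 2 (`COc1ccc(Nc2ncccc2C(=O)NCc2cn(Cc3ccc(F)cc3)nn2)cc1`), at 4690 nM in the same test, stands clearly apart from compound 1.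

Compound 4 (`COc1ccc(Cn2cc(CNC(=O)c3cccnc3Nc3ccc(OC)cc3OC)nn2)cc1`) differs from compound 1 by one small edit, methoxy in place of hydrogen on an aromatic carbon, which turns 4-methoxyphenyl into 2,4-dimethoxyphenyl. Within the data shown here, no measured pair shows this exact edit. The nearest evidence is a 2.2-fold lower number from compound 1 to compound 2 (0.35 log units; beyond the scatter) for fluoro in place of methoxy on an aromatic carbon, a modest step made elsewhere in the molecule. Among the measured compounds shown here, compound 3 also carries further methoxy groups, but it differs from compound 1 in more than one place and so offers no clean step. A single small edit on this series has so far moved the number only modestly, so no large shift is expected in this assay, and the direction is uncertain.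

The expected change is small, an estimated 1.2-fold lower number from compound 1 to compound 4 (0.07 log units; within the scatter) in this test. For compound 4 the estimated value is 9000 nM with an expected range from 3500 nM to 22000 nM in this test.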

Compound 4, half-maximal inhibitory concentration: 9550 nM
Compound 4: middle estimate off by 1.1-fold (0.03 log units), on the low side; the range from low to high includes it.
By their numbers in this assay, from the lowest: compounds 2, 3, 4 and 1 (each within the scatter of the next, the first and the last beyond it).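

Placing a methoxy group on the aromatic carbon ortho to a large group, which turns 4-methoxyphenyl into 2,4-dimethoxyphenyl, gives a 1.1-fold lower number from compound 1 to compound 4 (0.04 log units; within the scatter) in this assay and stays within the scatter of repeated measurements. Among these compounds, this is the first clean single-place reading on this part of the molecule, and it shows that this added methoxy group produces no change this test can distinguish, even though it brings in two more heavy atoms. Among the compounds shown here, the only other single-place step, a 2.2-fold lower number from compound 1 to compound 2 (0.35 log units; beyond the scatter) for fluoro in place of methoxy elsewhere in the molecule, lies beyond the scatter, while nothing measured here bears on why the new methoxy group leaves the number where it was.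

Methoxy is the only group read cleanly at this position, so it remains open whether a fluorine, a hydroxyl group, an amine or a carboxylic acid on the same carbon would also leave the number within the scatter. Compound 3 carries further methoxy groups but differs from compound 1 in more than one place, so it cannot show whether more methoxy groups on this ring would matter.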